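A bromoalkenyl amide measured against an azide

The compounds below may be only part of what the source reports. "The series", "measured", "known", "first", "only" and "open" are said of these compounds alone.

Compound 1 (`CCCCC(=O)N(Cc1ccc(OC)c(O)c1)c1cc(OC)c(OC)c(OC)c1`) gives 300 nM in a functional assay on KYSE-450 cells (Homo sapiens) for inhibition, read by MTT assay, with a stated time of 48 h (on this read-out higher numbers stand for weaker inhibition and lower numbers for stronger inhibition), and sets the reference for this small series of amides. Compound 2 (`COc1ccc(CN(C(=O)C=C(C)C)c2cc(OC)c(OC)c(OC)c2)cc1O`) gives 280 nM on the same read-out. Compound 3 (`COc1ccc(CN(C(=O)CN=[N+]=[N-])c2cc(OC)c(OC)c(OC)c2)cc1O`) gives 160 nM and stands within the scatter of both others, so the three cannot be ranked.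

Compound 4 (`COc1ccc(CN(C(=O)/C=C/CBr)c2cc(OC)c(OC)c(OC)c2)cc1O`) has not yet been measured. It carries 3-bromoprop-1-en-1-yl in place of azidomethyl on a carbonyl carbon. The nearest measured change is a 1.8-fold lower number from compound 2 to compound 3 (0.24 log units; within the scatter) and lies within the scatter, and there too an azidomethyl group is exchanged with an alkenyl group. The other two changes, a 1.1-fold lower number from compound 1 to compound 2 (0.03 log units; within the scatter) and a 1.9-fold lower number from compound 1 to compound 3 (0.27 log units; within the scatter), also lie within the scatter. Among the compounds with values here, no measured compound carries bromine, so that part of the change remains untested and the range has to stay wide.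

On this evidence, no step beyond the scatter is expected in this assay here. The estimated step is a 1.1-fold higher number from compound 3 to compound 4 (0.05 log units; within the scatter) and is expected to stay within the scatter. For compound 4 the estimated value is 180 nM with an expected range from 70 nM to 450 nM on this read-out.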

Compound 4, half-maximal inhibitory concentration: 100 nM
Compound 4: middle estimate off by 1.8-fold (0.26 log units), on the high side, and the stated range covers the measured number.
By their numbers in this assay, from the lowest: compounds 4, 3, 2 and 1 (each within the scatter of the next, the first and the last beyond it).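

In this assay, within the data shown here, the 3-bromoprop-1-en-1-yl group on the carbonyl carbon is the only group of the four whose steps pass beyond the scatter, with a 2.8-fold lower number from compound 2 to compound 4 (0.45 log units; beyond the scatter) and a 3.0-fold lower number from compound 1 to compound 4 (0.48 log units; beyond the scatter), both modest. Against azidomethyl the same group stays within the scatter, at a 1.6-fold lower number from compound 3 to compound 4 (0.20 log units; within the scatter), so compound 3 and compound 4 cannot be separated at this position. Compound 2 also carries an alkenyl group on the carbonyl carbon, yet a 1.1-fold lower number from compound 1 to compound 2 (0.03 log units; within the scatter) stays within the scatter, so among these compounds a double bond at this place does not by itself go with a step beyond the scatter.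

Nothing among the data shown accounts for the steps reached by the bromine-bearing group. Going by these compounds, it also remains open whether the bromine itself matters, which a 3-chloroprop-1-en-1-yl group, a 3-aminoprop-1-en-1-yl group or an unsubstituted prop-1-en-1-yl group on the same carbonyl carbon could help to show.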